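The compounds below may be only part of what the source reports. "The series", "measured", "known", "first", "only" and "open" are said of these compounds alone.

In a functional assay on HCT-116 cells (Homo sapiens) for antiproliferative activity, read by MTT assay, with a stated time of 48 h (on this read-out lower numbers stand for stronger inhibition and higher numbers for weaker inhibition), compound 1 (`COc1ccc(-c2cc3c(cn2)[nH]c(=O)n3-c2cc(OC)c(OC)c(OC)c2)cc1`) gives 840 nM and compound 2 (`CCOc1ccc(-c2cc3c(cn2)[nH]c(=O)n3-c2cc(OC)c(OC)c(OC)c2)cc1`) gives 6660 nM. Compound 2 therefore holds the higher of the two numbers and is the weaker inhibitor of the pair. Compound 3 (`CCOc1ccc(-c2cc3c(cn2)[nH]c(=O)n3-c2cc(OC)c(OC)c(OC)c2)cc1F`) keeps the ethoxy group of compound 2 and differs from it in one place: fluoro in place of hydrogen on an aromatic carbon. This is fluoro in place of hydrogen on an aromatic carbon, ortho to an ethoxy group. Among the measured compounds shown here, the only measured step is a 7.9-fold higher number from compound 1 to compound 2 (0.90 log units; beyond the scatter). It concerns a saturated chain carbon rather than an aromatic carbon, so it bears on the new change only indirectly, showing that a small edit can move the number beyond the scatter in this series. For the measured compounds named here, no measured compound carries fluoro, so the data give no direct guide to its size or direction. The expectation therefore stays close to compound 2 at 6660 nM, with only a slight lean towards a lower number. The expected step is a 1.3-fold lower number from compound 2 to compound 3 (0.12 log units; within the scatter), a shift not expected to exceed the scatter. Compound 3 is estimated at 5000 nM, with an expected range from 1800 nM to 14000 nM.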

Compound 3, half-maximal inhibitory concentration: 7220 nM
Compound 3: the middle estimate sits 1.4-fold (0.16 log units) below what was measured, and the stated range covers the measured number.
By their numbers in this assay, from the lowest: compound 1; then compounds 2 and 3 (each within the scatter of the next).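

In this assay, among the compounds shown here, the new step reads a 1.1-fold higher number from compound 2 to compound 3 (0.04 log units; within the scatter), so on the six-membered aromatic ring of compound 2, fluoro in place of hydrogen ortho to the ethoxy group leaves a difference that cannot be told from the scatter, and this is the first sign that a small edit need not shift the number. The combined replacement of 4-methoxyphenyl by 4-ethoxy-3-fluorophenyl reads an 8.6-fold higher number from compound 1 to compound 3 (0.93 log units; beyond the scatter), which places compound 1 apart from both ethoxy compounds and shows that fluoro does not close the gap opened by a 7.9-fold higher number from compound 1 to compound 2 (0.90 log units; beyond the scatter). No available measurement bears on why the fluoro step turns out this way.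

The compounds shown leave open whether fluoro on the same ring of compound 1, which carries the methoxy group, would also stay within the scatter, and whether chloro, a nitrile or an amine on that ring carbon would do the same. They also leave open how a propoxy chain or a hydroxyl group in place of the ethoxy group would read in this assay.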